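One stereocentre changed in a high-valued compound

A few compounds are considered here, and "the series" means these few. Any claim that something is new, unique, unknown or untested is made for them only; others in the source may bear on it.

Compound 1 `CCCCCCCOc1nccnc1C1CN2CCC1CC2` gives 400000 nM
Compound 2 `CCCCCCSc1nccnc1C1CN2CCC1CC2` gives 270000 nM
Compound 3 `CCCCCCOc1nccnc1[C@@H]1CN2CCC1C2` gives 13100000 nM

In a functional assay on A9L-m1 cells with A9 (Mus musculus) as the target (a lower number here means that less compound is needed, a higher number that more compound is needed for the effect), compound 3 gives 13100000 nM as the highest number of the three, so it needs the most compound for the effect. Its gaps to compound 1 and to compound 2 both lie beyond the scatter.

The compound still to be measured is compound 4 `CCCCCCOc1nccnc1[C@H]1CN2CCC1C2` and the change from compound 3 is small on paper. It is the two compounds have the same atoms and bonds; at least one stereo element is drawn with a configuration in one of them and without one in the other: 1 of 3 stereo elements differ; a stereocentre at a saturated ring carbon is drawn S in compound 3 and R in compound 4 (the two compounds have the same atoms and bonds, and a stereocentre at a saturated ring carbon is drawn S in compound 3 and R in compound 4).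

Among the compounds with values here, no two measured compounds differ only at a stereocentre, so the data give no direct guide to the size of such a step. A step beyond the scatter towards a lower number in this assay is still expected, though with little certainty. That expectation rests on compound 3 at 13100000 nM standing well above compound 1 at 400000 nM in the same series. The expected change is a 4.4-fold lower number from compound 3 to compound 4 (0.64 log units; beyond the scatter) as a rough estimate. For compound 4 the estimated value is 3000000 nM within an expected range of 200000 nM to 30000000 nM until a measurement is available.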

Compound 4, half-maximal effective concentration: 730000 nM
Compound 4: the middle estimate sits 4.1-fold (0.61 log units) above what was measured; low and high end bracket the measured number.
By their numbers in this assay, from the lowest: compounds 2, 1 and 4 (each within the scatter of the next, the first and the last beyond it); then compound 3.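

Within the data shown here, until now, no two compounds in this assay differed only at a stereocentre, so the size of such a change was unknown. Swapping the saturated ring carbon from S in compound 3 to R in compound 4 gives an 18-fold lower number from compound 3 to compound 4 (1.25 log units; beyond the scatter), a large step with the atoms and bonds unchanged. This shows that the assay responds strongly to the configuration at this one ring carbon, with the R drawing needing less compound for the effect, and the step can be tied to that single place in the structures: the fact that one of compounds 3 and 4 is drawn with a defined configuration and the other without, at the place where they differ

Among the compounds shown, this is the only pair that differs only at a stereocentre, so it remains open whether R would also give the lower number with a different chain or core. From the compounds shown here alone, it is also open how a terminal amine or a carboxylic acid on the chain would change the number with either configuration at this ring carbon.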